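The source may report more compounds than this note shows. Statements on the series, on what has been measured and on what is new or still open speak of the compounds shown alone.

Measured compounds:
Compound 1 `CC(C)C(c1ncco1)c1ccc(-c2ccc3cccc(F)c3c2)[nH]c1=O`, 0.178 h
Compound 2 `CCn1ncc2c(F)cc(-c3ccc(C(CC)(CC)c4nnc(C)[nH]4)c(=O)[nH]3)cc21`, > 3 h

For the measured compounds named here, in an ADME assay on microsomes from liver (Homo sapiens) for metabolic stability (a lower number here means that the compound disappears faster, a higher number that the compound lasts longer), compound 1 gives 0.178 h, the only plain number among the two values. Compound 2 gives > 3 h, which is a limit of the assay rather than a number. Going by the values given here, the picture is therefore set by the limit of > 3 h in this assay, at which 1 of the 2 values shown sits, on one side and by the short half-life of compound 1 on the other, with no step between two measured compounds that differ in one place.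

Compound 3 `CC(C)NC(=O)CC(c1ccc(-c2ccc3cccc(F)c3c2)[nH]c1=O)C(C)C` differs from compound 1 by (isopropylcarbamoyl)methyl in place of 1,3-oxazol-2-yl on a saturated chain carbon bound to an aromatic carbon and a saturated chain carbon. Among the compounds with values here, no measured step guides this change. The expectation is a step of a 1.7-fold higher number from compound 1 to compound 3 (0.23 log units; within the scatter), a modest gain that may not clear the usual scatter. Compound 3 is expected to give 0.3 h, with a likely range from 0.1 h to 0.9 h.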

Compound 3, half-life: 0.32 h
The estimate for compound 3 lay 1.1-fold (0.03 log units) below the measured number, within the range that was stated.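

In this assay, putting (isopropylcarbamoyl)methyl in place of 1,3-oxazol-2-yl on a saturated chain carbon bound to an aromatic carbon and a saturated chain carbon gives a 1.8-fold higher number from compound 1 to compound 3 (0.25 log units; within the scatter). For the compounds shown here, as the only measured step at this position, it shows that a group with no ring and one hydrogen-bond donor can stand in for the five-membered aromatic ring without a change in half-life that clears the scatter. Nothing measured here accounts for the size of this step.

Compound 2 gives > 3 h, which is a limit of the assay, and it differs from compound 1 and compound 3 in more than one place, so it does not show which part sets that result. As far as these compounds go, whether an amine or a carboxylic acid on this chain carbon would move the half-life beyond the scatter remains open.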